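This account rests on a few compounds, and the source may have more. Where it says the series, first, only, none or still open, it means among the compounds named here.

Measured compounds in the series:

Compound 1 `CC1CCC(Nc2nc(C(F)(F)F)ccc2CNC(=O)C(C)c2ccc(NS(C)(=O)=O)c(F)c2)CC1`: in a functional assay on CHO-K1 cells for antagonist activity at transient receptor potential cation channel subfamily V member 1 (Homo sapiens), read by FLIPR (a higher number here means a weaker inhibitor, a lower number a stronger inhibitor), compound 1 gives 27.2 nM.
Compound 2 `CC(C(=O)NCc1ccc(C(F)(F)F)nc1Nc1ccc(F)cc1)c1ccc(NS(C)(=O)=O)c(F)c1`: compound 2 gives 39.2 nM.
Compound 3 `CC(C(=O)NCc1ccc(C(F)(F)F)nc1N(C)C)c1ccc(NS(C)(=O)=O)c(F)c1`: compound 3 gives 19.1 nM.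

Compound 2 carries the highest of the three numbers. Its nearest neighbour is compound 1, with a 1.4-fold higher number from compound 1 to compound 2 (0.16 log units; within the scatter), a gap that stays within the scatter. Against compound 3 the gap is a 2.1-fold lower number from compound 2 to compound 3 (0.31 log units; beyond the scatter), a modest step that does pass the scatter. Compound 3 also sits within the scatter of compound 1, as a 1.4-fold lower number from compound 1 to compound 3 (0.15 log units; within the scatter) shows.

Compound 4 `CC(C(=O)NCc1ccc(C(F)(F)F)nc1N(C)c1ccccc1)c1ccc(NS(C)(=O)=O)c(F)c1` is not yet measured. It differs from compound 2 by methyl(phenyl)amino in place of (4-fluorophenyl)amino on an aromatic carbon.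

Going by the values given here, of the measured steps, only the step from compound 2 to compound 3 bears directly on this change, since both it and the present step replace the (4-fluorophenyl)amino group with a group that has no hydrogen-bond donor. That step was modest. The step from compound 1 to compound 2, exchanging 4-methylcyclohexyl for 4-fluorophenyl on the same nitrogen, stayed within the scatter, so the aromatic ring itself seems to matter little here. A small move downward or none beyond the scatter is therefore expected in this assay, in line with a 1.3-fold lower number from compound 2 to compound 4 (0.12 log units; within the scatter).

Compound 4 is estimated at 30 nM, with a range from 12 nM to 75 nM.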

Compound 4, inhibition constant: 0.9 nM
For compound 4 the middle estimate is 33-fold (1.52 log units) above the measured one; measured number below the stated range.
By their numbers in this assay, from the lowest: compound 4; then compounds 3, 1 and 2 (each within the scatter of the next, the first and the last beyond it).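

In this assay, going by these compounds alone, the substituent on the aromatic carbon next to the ring nitrogen turns out to be far more sensitive than the earlier compounds indicated, with a 44-fold lower number from compound 2 to compound 4 (1.64 log units; beyond the scatter) on moving to methyl(phenyl)amino. Neither part of that group is enough alone: dimethylamino already carries a methyl on the nitrogen, yet phenyl in place of one methyl gives a 21-fold lower number from compound 3 to compound 4 (1.33 log units; beyond the scatter), and the (4-methylcyclohexyl)amino compound trails too, with a 30-fold lower number from compound 1 to compound 4 (1.48 log units; beyond the scatter) on the same change of group. Among these four compounds, the gain appears only where methyl and phenyl share the nitrogen, and no measurement shown explains it.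

Loss of the fluorine and gain of the methyl coincide between compound 2 and compound 4, so their shares remain unseparated; methyl(4-fluorophenyl)amino would address that. Ethyl(phenyl)amino would show whether the methyl can be lengthened.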